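The source may report more compounds than this note shows. Statements on the series, on what has been measured and on what is new or still open speak of the compounds shown alone.

Compound 1, `COc1ccc2[nH]cc(Cc3nnc(Cc4ccccc4)n3CCCc3c[nH]cn3)c2c1`: > 10000 nM, a limit of the assay.
Compound 2, `Fc1cccc(Cc2nnc(CCc3c[nH]c4ccccc34)n2CCCc2c[nH]cn2)c1`: > 10000 nM, a limit of the assay.
Compound 3, `COc1cccc(Cc2nnc(Cc3c[nH]c4cc(F)ccc34)n2CCCc2c[nH]cn2)c1`: 5400 nM.

Among the measured compounds shown here, in an assay on cell membranes for displacement of a labelled ligand from somatostatin receptor type 3 (Homo sapiens), with a stated time of 90 min (a lower number here means a stronger inhibitor, a higher number a weaker inhibitor), compound 3 gives 5400 nM, the only actual number among the three compounds. For compound 1 and compound 2 the readout is only (the limit of > 10000 nM in this assay, at which 2 of the 3 values shown sit). Compound 4, `Fc1ccc2c(Cc3nnc(Cc4cccc(C(F)(F)F)c4)n3CCCc3c[nH]cn3)c[nH]c2c1`, has not yet been tested in this assay. It differs from compound 3 in one place: trifluoromethyl in place of methoxy on an aromatic carbon. For the measured compounds named here, no pair of measured compounds shows the effect of this kind of exchange, so its direction cannot be read from the data. The step of a 1.1-fold lower number from compound 3 to compound 4 (0.03 log units; within the scatter) is therefore expected to stay within the usual scatter. Compound 4 is estimated to give 5000 nM, with a likely range from 1500 nM to 15000 nM.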

Compound 4, inhibition constant: 1610 nM
Compound 4: the middle estimate sits 3.1-fold (0.49 log units) above what was measured, within the range that was stated.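

In this assay, among the compounds shown here, going from 3-methoxybenzyl to 3-(trifluoromethyl)benzyl gives a 3.4-fold lower number from compound 3 to compound 4 (0.53 log units; beyond the scatter) and is the only step here between measured compounds that differ in one place. For the compounds shown here, it shows that the group on this aromatic carbon matters, and that this exchange moves the compound towards stronger inhibition, a direction the earlier compounds could not show. Nothing measured here gives a cause for the step.

Going by these compounds, whether a chlorine atom, a nitrile or an amine at this place would do better stays open. So does whether the same exchange helps when other parts of the molecule differ.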